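Aryl swap from compound 3 to compound 4

The compounds below may be only part of what the source reports. "The series", "measured", "known", "first", "only" and "open" are said of these compounds alone.

Values measured in an ADME assay on WI-38 cells (Homo sapiens) for cytotoxicity, read by MTT assay, with a stated time of 72 h (a higher number here means a weaker inhibitor, a lower number a stronger inhibitor), are as follows.
compound 1 `O=C(CCc1cccc2c1B(O)OC2)Nc1cccc(-c2ccc(Cl)cc2)c1` gives 9800 nM
compound 2 `CSc1cccc(-c2cccc(NC(=O)CCc3cccc4c3B(O)OC4)c2)c1` gives 2000 nM
compound 3 `CSc1ccc(-c2cccc(NC(=O)CCc3cccc4c3B(O)OC4)c2)cc1` gives 3800 nM

Among these three numbers compound 3 cannot be separated from compound 2 given a 1.9-fold higher number from compound 2 to compound 3 (0.28 log units; within the scatter) and it lies clear of compound 1 given a 2.6-fold lower number from compound 1 to compound 3 (0.41 log units; beyond the scatter) in these notes.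

Compound 4 `O=C(CCc1cccc2c1B(O)OC2)Nc1cccc(-c2cccc(C(F)(F)F)c2)c1` remains unmeasured. It carries 3-(trifluoromethyl)phenyl in place of 4-(methylsulfanyl)phenyl on an aromatic carbon with 3-(trifluoromethyl)phenyl in place of 4-(methylsulfanyl)phenyl on an aromatic carbon.

Within the data shown here, no measured compound holds a trifluoromethyl group, so the evidence is indirect. Exchanging 3-(methylsulfanyl)phenyl for 4-(methylsulfanyl)phenyl gave only a 1.9-fold higher number from compound 2 to compound 3 (0.28 log units; within the scatter) while the changes away from the chloro compound were modest, at a 4.9-fold lower number from compound 1 to compound 2 (0.69 log units; beyond the scatter) and a 2.6-fold lower number from compound 1 to compound 3 (0.41 log units; beyond the scatter) in size. On that basis a small move towards a higher number is expected, with no step beyond the scatter in this assay as the likely outcome.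

The expected change is a 1.3-fold higher number from compound 3 to compound 4 (0.12 log units; within the scatter) on this reasoning.

For compound 4 the estimate is 5000 nM with an expected range of 2000 nM to 12000 nM for the coming measurement.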

Compound 4, half-maximal inhibitory concentration: 23000 nM
Estimate against measurement, compound 4: 4.6-fold (0.66 log units) below; the measured number lies above the stated range.
By their numbers in this assay, from the lowest: compounds 2 and 3 (each within the scatter of the next); then compound 1; then compound 4.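

In this assay, this position proves able to shift the number far more than the methylsulfanyl isomers suggested: those two sat at a 1.9-fold higher number from compound 2 to compound 3 (0.28 log units; within the scatter), whereas trifluoromethyl gives a 12-fold higher number from compound 2 to compound 4 (1.06 log units; beyond the scatter) and the full aryl exchange gives a 6.1-fold higher number from compound 3 to compound 4 (0.78 log units; beyond the scatter) in the same series. The 3-(trifluoromethyl)phenyl group is also the first replacement of 4-chlorophenyl to move upward, at a 2.3-fold higher number from compound 1 to compound 4 (0.37 log units; beyond the scatter), so aryl exchanges here run in both directions and compound 4 holds the highest number of the four. Nothing available on these compounds accounts for the rise.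

Trifluoromethyl appears at one place only, so the effect of the group and that of its place remain unseparated. From the compounds shown here alone, how an amine or a carboxylic acid on this aryl ring would fall relative to these compounds also remains open.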